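Trading a sulfonyl group for a dichlorobenzyl sulfanyl group

The source may hold more compounds than are shown below. What is called first, only, known or untested is meant among the compounds shown, and "the series" means these compounds.

- Compound 1 `Cc1ccc(/C=C(/SCc2ccc(Cl)cc2Cl)C(=O)c2ccc(Cl)cc2)s1`: 50000 nM
- Compound 2 `Cc1ccc(S/C(=C/c2ccc(N(C)C)cc2)C(=O)c2ccc(Cl)cc2)cc1`: > 100000 nM (a limit)
- Compound 3 `Cc1ccc(S(=O)(=O)/C(=C/c2ccc(N(C)C)cc2)C(=O)c2ccc(Cl)cc2)cc1`: > 100000 nM (a limit)

In a functional assay on DU-145 cells (Homo sapiens) for inhibition, read by trypan blue exclusion, with a stated time of 96 h (a lower number here means a stronger inhibitor of growth, a higher number a weaker inhibitor of growth), compound 3 gives > 100000 nM, which is a limit of the assay and not a number. Compound 2 sits at the same limit. Within the data shown here, the only measured step, a step that the two limits leave unreadable from compound 2 to compound 3, therefore offers no size to build on.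

Compound 4 `CN(C)c1ccc(/C=C(/SCc2ccc(Cl)cc2Cl)C(=O)c2ccc(Cl)cc2)cc1` has (2,4-dichlorobenzyl)sulfanyl in place of (4-methylphenyl)sulfonyl on a double-bonded chain carbon bound to a carbonyl carbon and a double-bonded chain carbon. Compound 1 carries the same (2,4-dichlorobenzyl)sulfanyl group and gives 50000 nM, so a shift towards stronger inhibition is expected for compound 4, although the rest of compound 1 differs. The expected move is an at least 2.0-fold lower number from compound 3 to compound 4 (0.30 log units; that floor lies within the scatter). Compound 4 is estimated at 50000 nM, within an expected range of 15000 nM to 100000 nM.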

Compound 4, concentration for 50% growth inhibition: 50000 nM
Compound 4: middle estimate and measured number agree at the digits printed; low and high end bracket the measured number.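

At this position, (2,4-dichlorobenzyl)sulfanyl gives a readable number where the two earlier groups gave only a limit, with an at least 2.0-fold lower number from compound 3 to compound 4 (0.30 log units; that floor lies within the scatter) and an at least 2.0-fold lower number from compound 2 to compound 4 (0.30 log units; that floor lies within the scatter). On these data alone, both steps are only floors, and the true sizes stay unknown because compound 2 and compound 3 sit at a limit: the limit of > 100000 nM in this assay, at which 2 of the 4 values shown sit. With that sulfanyl group held, 4-(dimethylamino)phenyl in place of 5-methylthiophen-2-yl gives no change at the digits printed from compound 1 to compound 4 (within the scatter).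

Still open, as far as these compounds go, is whether the chlorines matter, or whether a plain benzyl group on the sulfur would serve equally well.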